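Swapping the Five-Membered Ring on the Amide Carbonyl

The source may report more compounds than this note shows. Statements on the series, on what has been measured and on what is new or still open speak of the compounds shown alone.

Compound 2 `COc1cc2c(Oc3ccc(NC(=O)c4nnc(-c5ccc(F)cc5)o4)cc3)ccnc2cc1OCCCN1CCC(C)CC1` gives 3810 nM in a functional assay on PC-3 cells (Homo sapiens) for antiproliferative activity, read by MTT assay, with a stated time of 72 h (a higher number here means a weaker inhibitor, a lower number a stronger inhibitor), the highest of the two numbers recorded, its nearest neighbour being compound 1 `COc1cc2c(Oc3ccc(NC(=O)c4cc(-c5ccc(F)cc5)on4)cc3)ccnc2cc1OCCCN1CCC(C)CC1` at 2040 nM. Among the compounds with values here, the one measured step, a 1.9-fold higher number from compound 1 to compound 2 (0.27 log units; within the scatter), lay within the scatter. Compound 3 `COc1cc2c(Oc3ccc(NC(=O)c4ncc(-c5ccc(F)cc5)o4)cc3)ccnc2cc1OCCCN1CCC(C)CC1` carries 5-(4-fluorophenyl)-1,3-oxazol-2-yl in place of 5-(4-fluorophenyl)-1,3,4-oxadiazol-2-yl on a carbonyl carbon. That earlier step is the only one that bears on this change, and it was small, so the step in this assay is expected to stay within the scatter, with perhaps a slight drift toward a lower number. Compound 3 is therefore estimated at 2600 nM, in a range from 900 nM to 7500 nM, which means a 1.5-fold lower number from compound 2 to compound 3 (0.17 log units; within the scatter).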

Compound 3, half-maximal inhibitory concentration: 720 nM
Compound 3: the middle estimate sits 3.6-fold (0.56 log units) above what was measured, and the stated range ends above it.
By their numbers in this assay, from the lowest: compound 3; then compounds 1 and 2 (each within the scatter of the next).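

In this assay the five-membered ring on the carbonyl carbon now clearly matters, which the earlier step within the scatter did not show. With 5-(4-fluorophenyl)-1,3-oxazol-2-yl in place, the result is a 5.3-fold lower number from compound 2 to compound 3 (0.72 log units; beyond the scatter) and also a 2.8-fold lower number from compound 1 to compound 3 (0.45 log units; beyond the scatter) so compound 3 is the most potent of the three. Nothing available accounts for this difference.

The compounds shown leave open whether the gain persists with a chlorine or a methoxy group in place of the fluorine. They also leave open whether a thiazole ring would match the 1,3-oxazole.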